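From methoxy to trifluoromethyl on the shared core

The source may hold more compounds than are shown below. What is called first, only, known or untested is meant among the compounds shown, and "the series" means these compounds.

In an ADME assay on HaCaT cells (Homo sapiens) for cytotoxicity, read by MTT assay, with a stated time of 48 h (on this read-out higher numbers stand for weaker inhibition and lower numbers for stronger inhibition), compound 1 (`Clc1ccc(-c2nn(-c3ccccc3)cc2-c2nc3cc(Cl)ccc3[nH]2)cc1`) gives > 50000 nM as a limit of the assay and not a number. In this assay compound 2 (`COc1ccc2[nH]c(-c3cn(-c4ccccc4)nc3-c3ccc(Cl)cc3)nc2c1`) gives > 50000 nM as a limit too and not a number. Within the data shown here, compound 2 therefore has no exact place on the numbers so far. All readings in hand stand at the limit of > 50000 nM in this assay, at which 2 of the 2 values shown sit, and none is a true number.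

Compound 3 (`FC(F)(F)c1ccc2[nH]c(-c3cn(-c4ccccc4)nc3-c3ccc(Cl)cc3)nc2c1`) carries trifluoromethyl in place of methoxy on an aromatic carbon of the six-membered ring of carbon only (trifluoromethyl in place of methoxy on an aromatic carbon is the counted difference). Among the measured compounds shown here, the one measured step that bears on this change is a step that the two limits leave unreadable from compound 1 to compound 2 and it offers neither a size nor a direction to carry over. No step beyond the usual scatter is therefore expected in this assay and a further limit reading for compound 3 is quite likely. The expected change is a number no higher from compound 2 to compound 3 (the limit leaves the size open) as estimated here. For compound 3 the estimate is 50000 nM with an expected range of 20000 nM to 100000 nM at this stage.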

Compound 3, half-maximal inhibitory concentration: 41800 nM
The estimate for compound 3 lay 1.2-fold (0.08 log units) above the measured number; measured number inside the range.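

In this assay, among these compounds, compound 3 gives 41800 nM, the first reading that is a true number rather than a limit, which shows that a number can be obtained on the shared core with trifluoromethyl on this aromatic carbon of the six-membered ring. Trifluoromethyl in place of methoxy gives an at least 1.1-fold lower number from compound 2 to compound 3 (0.07 log units; that floor lies within the scatter), and trifluoromethyl in place of chloro gives an at least 1.1-fold lower number from compound 1 to compound 3 (0.07 log units; that floor lies within the scatter). Compound 1 and compound 2 both remain at a limit and not a number, so each of these steps is only a floor, and neither establishes a change beyond the scatter: the limit of > 50000 nM in this assay, at which 2 of the 3 values shown sit.

Going by these compounds, the true sizes of these steps remain open, as does any order among chloro, methoxy and trifluoromethyl, and the step between compound 1 and compound 2 cannot be read. Also open, on these data alone, is how an amine, a carboxylic acid or a longer chain on this aromatic carbon would read in this assay, and whether any such group would give a step clearly beyond the scatter.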